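Adding a Carbon to the Butylamino Chain

A few compounds are considered here, and "the series" means these few. Any claim that something is new, unique, unknown or untested is made for them only; others in the source may bear on it.

Compound 1 `CCCOc1ccc(C(=O)Nc2cccc(C)n2)cc1`: 7500 nM
Compound 2 `CCCOc1ccc(C(=O)Nc2cccc(CC)n2)cc1`: 37600 nM
Compound 3 `CCCCNc1cccc(NC(=O)c2ccc(OCCC)cc2)n1`: 54100 nM

These numbers come from an in vitro assay on HEK-tsA201 cells for antagonist activity at Neuronal acetylcholine receptor; alpha4/beta2 (Homo sapiens), read by fluorescence and calcium flux; a higher number here means a weaker inhibitor, a lower number a stronger inhibitor. Compound 2 differs from compound 1 by methyl in place of hydrogen on a saturated chain carbon bound to an aromatic carbon, and that gave a 5.0-fold higher number from compound 1 to compound 2 (0.70 log units; beyond the scatter). Compound 3 differs from compound 1 by butylamino in place of methyl on an aromatic carbon, worth a 7.2-fold higher number from compound 1 to compound 3 (0.86 log units; beyond the scatter); against compound 2 it shows a 1.4-fold higher number from compound 2 to compound 3 (0.16 log units; within the scatter). Compound 4 `CCCCCNc1cccc(NC(=O)c2ccc(OCCC)cc2)n1` is not yet measured in this assay. It differs from compound 3 by methyl in place of hydrogen on a saturated chain carbon, four bonds along the chain from a nitrogen on an aromatic ring. This is the same kind of change as that from compound 1 to compound 2, but the place is not the same: there the methyl entered on a saturated chain carbon bound to an aromatic carbon, here on a saturated chain carbon four bonds along the chain from a nitrogen on an aromatic ring. The earlier step was a 5.0-fold higher number from compound 1 to compound 2 (0.70 log units; beyond the scatter), and compound 3 starts from 54100 nM. The place differs, so a smaller step is expected, and compound 4 is expected to shift by a 1.2-fold higher number from compound 3 to compound 4 (0.08 log units; within the scatter). The estimate for compound 4 in this assay is 65000 nM, expected between 25000 nM and 170000 nM.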

Compound 4, half-maximal inhibitory concentration: > 100000 nM
Compound 4 was reported as a limit; the forecaster's own chance of this, stated with the estimate: 30%; middle value at least 1.5-fold (0.18 log units) away from the limit.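

In this assay compound 4 gives > 100000 nM, which is a limit of the assay and not a number. Even so, the limit can be read as a floor against the two other compounds, giving an at least 2.6-fold higher number from compound 2 to compound 4 (0.42 log units; beyond the scatter) and an at least 13-fold higher number from compound 1 to compound 4 (1.12 log units; beyond the scatter). The added methyl gives an at least 1.8-fold higher number from compound 3 to compound 4 (0.26 log units; that floor lies within the scatter), so the change can be set beside the earlier step only in part, and the data do not show whether it carries over from one core to the other with the same size: the same change on two cores in this assay, a 5.0-fold higher number (0.70 log units; beyond the scatter) from compound 1 to compound 2 and an at least 1.8-fold higher number (0.26 log units; that floor lies within the scatter) from compound 3 to compound 4; the limit leaves it open whether they differ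

The compounds shown leave open whether propylamino or ethylamino in place of butylamino would bring the number closer to that of compound 1. They also leave open how a chain carrying a hydroxyl or a carboxylic acid would read.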